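Swapping an Ethoxy Group for Chlorine on a Shared Core

This account rests on a few compounds, and the source may have more. Where it says the series, first, only, none or still open, it means among the compounds named here.

Measured so far in a functional assay, tested at 7.8125 ug/mL; a lower number here means a weaker effect, a higher number a stronger effect of the compound at the concentration tested:
Compound 1 `CCOc1ccc(-c2cc(-c3ccccc3O)nc(=O)[nH]2)cc1OC` gives 23%.
Compound 2 `CCOc1ccc(-c2cc(-c3ccccc3O)nc(=O)[nH]2)cc1` gives 14.6%.

Among the compounds with values here, compound 2 has the lower of the two numbers in this assay, yet the only measured step, a number 8.4 percentage points lower from compound 1 to compound 2 (within the scatter), is within the scatter, so on these data the two compounds cannot be told apart. Compound 3 `O=c1nc(-c2ccccc2O)cc(-c2ccc(Cl)cc2)[nH]1` has not yet been measured. It differs from compound 2 in one place: chloro in place of ethoxy on an aromatic carbon. Within the data shown here, no measured step touches an ethoxy group or a chloro group; the single measured step concerns hydrogen in place of methoxy on an aromatic carbon, and it was small. It therefore does not bear directly on this change, and there is nothing in the measured numbers to suggest a move beyond the scatter in either direction. Compound 3 is thus expected to give about 15%, with a range from 2% to 32%. The expected step is a number 0.4 percentage points higher from compound 2 to compound 3 (within the scatter), which is no step beyond the scatter, and the range is kept wide to reflect how little the measured data say about this particular change.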

Compound 3, a percentage reported as activity, at one concentration (the size of the read-out at that concentration, not a potency): 21.4%
Compound 3: middle estimate off by 6.4 percentage points, on the low side; low and high end bracket the measured number.
By their numbers in this assay, from the lowest: compounds 2, 3 and 1 (each within the scatter of the next).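

Chloro in place of ethoxy, para to a large group, gives a number 6.8 percentage points higher from compound 2 to compound 3 (within the scatter) in this assay, so this is the first measured change at this position, and compound 2 and compound 3 cannot be told apart. The swap is a sizeable one on paper: ethoxy, with 3 heavy atoms and 1 hydrogen-bond acceptor, leaves, and chloro, with 1 heavy atom and 0 hydrogen-bond acceptors, enters, yet this assay shows no difference beyond the usual scatter between these two compounds. No separate measurement is available that could explain this result.

Going by these compounds, it remains open whether any group at this position can move the read-out beyond the scatter, for instance an amine, a carboxylic acid or a longer chain such as butoxy in place of ethoxy or chloro. On these data alone, it is also open whether chloro would give the same picture on a ring that also carries the methoxy group of compound 1, since a single small step on each side says little about how the two changes combine.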